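Replacing a Piperidine Urea with a Fluorobenzamide

The source may hold more compounds than are shown below. What is called first, only, known or untested is meant among the compounds shown, and "the series" means these compounds.

Of the compounds shown here, two sharing one core have been measured in an assay on HEK293 cells for positive allosteric modulation of metabotropic glutamate receptor 5 (Homo sapiens), read by FLIPR; on this read-out lower numbers stand for an effect already at smaller amounts and higher numbers for an effect only at larger amounts of compound. Compound 1 `O=C(C1CCC(F)(F)CC1)N1CC(c2nc(-c3cccc(F)c3)no2)C1` gives 520 nM in this assay. Compound 2 `O=C(N1CCC(F)CC1)N1CC(c2nc(-c3cccc(Cl)c3)no2)C1` gives 990 nM in this assay. Going by the values given here, these two numbers lie within the usual scatter of each other, so no order between compound 1 and compound 2 can be read from them, and since the two structures differ in more than one place, no single structural step connects them.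

Compound 3 `O=C(c1ccc(F)cc1)N1CC(c2nc(-c3cccc(Cl)c3)no2)C1` is not yet measured. It differs from compound 2 by 4-fluorophenyl in place of 4-fluoropiperidin-1-yl on a carbonyl carbon. The carbonyl thus carries an aromatic ring instead of a saturated ring with a nitrogen, while the rest of the molecule is unchanged. Among the compounds with values here, there is no measured pair in this set that shows what such a change does, so the size and direction of the step remain open. Compound 3 is estimated to give 650 nM in this assay, between 150 nM and 2800 nM, which corresponds to an expected step of a 1.5-fold lower number from compound 2 to compound 3 (0.18 log units; within the scatter) that is no larger than the scatter itself.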

Compound 3, half-maximal effective concentration: > 10000 nM
Compound 3: a limit, no number; the forecaster's own chance of this, stated with the estimate: 10%; at least 15-fold (1.18 log units) between middle value and limit.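

In this assay compound 3 gives > 10000 nM, which is a limit of the assay and not a number. Going by these compounds alone, exchanging 4-fluoropiperidin-1-yl for 4-fluorophenyl on the carbonyl carbon is the first change in one place in this set, and it produces an at least 10-fold higher number from compound 2 to compound 3 (1.00 log units; beyond the scatter), so the identity of the ring at this position matters greatly on this read-out, even though the heavy-atom count stays the same and neither group has hydrogen-bond donors or acceptors. The true size of this step cannot be read, since one end of it is set by the assay's ceiling: the limit of > 10000 nM in this assay, at which 1 of the 3 values shown sits.

The compounds shown do not separate the presence of an aromatic ring from the absence of the ring nitrogen as the source of the step, and they give no reason for it. A cyclohexyl group on the same carbonyl would keep the saturated ring without the nitrogen, and a pyridinyl group would keep the aromatic ring with a nitrogen, so these two groups would bear directly on that open question.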